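Swapping a cyclobutylmethyl ether for an oxazole-bearing side chain

The source may report more compounds than this note shows. Statements on the series, on what has been measured and on what is new or still open speak of the compounds shown alone.

Of the compounds shown here, three have been measured in a physicochemical assay for lipophilicity, read by HPLC, at pH 7.4; a lower number here means a more polar compound, a higher number a more lipophilic compound. Compound 1 `Cc1ccc([C@@H](C)Oc2cc3onc(CCC(=O)O)c3cc2Cl)nc1` gives 2.42, and compound 3 `C[C@@H](Oc1cc2onc(CCC(=O)O)c2cc1Cl)c1ccc(F)cn1` gives 2.47; these two share a core and differ only as a number 0.05 log units higher from compound 1 to compound 3 (within the scatter), a step within the scatter. Compound 2 `O=C(O)CCn1c(=O)oc2cc(OCC3CCC3)c(Cl)cc21`, built on a different core, gives 2.9, the highest of the three numbers, standing beyond the scatter above both compound 3 and compound 1.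

Compound 4 `C[C@@H](Oc1cc2oc(=O)n(CCC(=O)O)c2cc1Cl)c1ncco1` keeps the core of compound 2 and changes one group: a group of 7 heavy atoms (5 carbon, 1 nitrogen, 1 oxygen; one five-membered aromatic ring with 2 hetero atoms) in place of a group of 5 heavy atoms (5 carbon; one four-membered non-aromatic ring of carbon only), on an oxygen on an aromatic ring. Within the data shown here, no measured step tracks this kind of exchange, since the only measured step, between compound 1 and compound 3, swaps a single substituent on an aromatic ring and stays within the scatter. The expectation therefore rests on compound 2 alone as a starting point, with the exchange of a carbon-only ring for a ring carrying two hetero atoms and two hydrogen-bond acceptors suggesting a move downward in this assay.

The estimated step is a number 1.00 log units lower from compound 2 to compound 4 (beyond the scatter). Compound 4 is expected to give 1.9, with a likely range from 1.4 to 2.4.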

Compound 4, distribution coefficient: 1.11
Compound 4: the middle estimate sits 0.79 log units above what was measured, and the stated range ends above it.
By their numbers in this assay, from the lowest: compound 4; then compounds 1 and 3 (each within the scatter of the next); then compound 2.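

In this assay, the group on an oxygen on an aromatic ring proves able to move the number a long way: cyclobutylmethyl giving way to the group with a five-membered aromatic ring with 2 hetero atoms is a number 1.79 log units lower from compound 2 to compound 4 (beyond the scatter) on the shared core. Among these compounds, the only earlier step, a number 0.05 log units higher from compound 1 to compound 3 (within the scatter) for a different exchange on another core, gave no sign of a shift this size. No measured evidence here accounts for the size of this step.

This single exchange alters several things at once, including the ring, its 2 hydrogen-bond acceptors and a defined stereocentre, so the compounds shown cannot say which of them matters. Also open, as far as these compounds go, is where a phenyl ring would fall at this oxygen, and whether the same exchange would produce a similar step on the core of compound 1.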